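A few compounds are considered here, and "the series" means these few. Any claim that something is new, unique, unknown or untested is made for them only; others in the source may bear on it.

Going by the values given here, compound 2 `COc1ccc(-c2cc3ccc(OCCCn4cc(CNC(=O)CCCCC5CCSS5)nn4)cc3oc2=O)cc1` is one of two compounds measured in a functional assay on PC-12 cells (Rattus norvegicus) for cytotoxicity, read by MTT assay, with stated times of 3 h and 2 h, tested at 20 uM (on this read-out lower numbers stand for a weaker effect and higher numbers for a stronger effect at the one concentration tested), where compound 2 gives 62%. Among the compounds with values here, its one neighbour, compound 1 `O=C(CCCCC1CCSS1)NCc1cn(CCCOc2ccc3cc(C(=O)O)c(=O)oc3c2)nn1`, gives 66.8% in this assay, and the step of a number 4.8 percentage points lower from compound 1 to compound 2 (within the scatter) leaves the two compounds within the scatter of each other, so neither can be called the stronger.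

Compound 3 `O=C(CCCCC1CCSS1)NCc1cn(CCCOc2ccc3cc(-c4ccc(Cl)cc4)c(=O)oc3c2)nn1` has not yet been measured. It differs from compound 2 in one place: chloro in place of methoxy on an aromatic carbon. Within the data shown here, no measured step covers this exchange of chloro for methoxy; the only measured step, which swaps carboxy for 4-methoxyphenyl, did not move the read-out beyond the scatter, and it concerns a different change. With nothing pointing in either direction, no step beyond the scatter is expected from compound 2 to compound 3, and the expected step is no change at the digits printed from compound 2 to compound 3 (within the scatter). Compound 3 is therefore estimated to give 62% in this assay, with a range from 48% to 76%.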

Compound 3, a percentage reported as activity, at one concentration (the size of the read-out at that concentration, not a potency): 75.6%
Estimate against measurement, compound 3: 13.6 percentage points below; measured number inside the range.
By their numbers in this assay, from the lowest: compounds 2, 1 and 3 (each within the scatter of the next, the first and the last beyond it).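

Going by these compounds alone, the exchange of methoxy for chloro on the aromatic ring gives a number 13.6 percentage points higher from compound 2 to compound 3 (beyond the scatter) in this assay and is the first step in this set to pass the scatter, so the group at this place on the 4-substituted phenyl can move the read-out. The 4-chlorophenyl group is not set apart from carboxy in the same way, since the step of a number 8.8 percentage points higher from compound 1 to compound 3 (within the scatter) leaves compound 3 and compound 1 unresolved. No measurement shown here bears on what lies behind the difference between chloro and methoxy.

With only chloro and methoxy shown on this phenyl ring, it remains open whether fluoro, methyl or an amine at the same place would read like compound 2 or like compound 3. As far as these compounds go, it also remains open whether the step from methoxy to chloro would persist with a longer chain in place of the present linker.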